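This account rests on a few compounds, and the source may have more. Where it says the series, first, only, none or still open, it means among the compounds named here.

Measured in a functional assay on HepG2 cells (Homo sapiens) for antiproliferative activity, read by MTT assay, with a stated time of 48 h; a higher number here means a weaker inhibitor, a lower number a stronger inhibitor:
compound 1 `COc1ccc(N(C)c2ccnc(Cl)n2)cc1Cl`, 2630 nM
compound 2 `COc1ccc(N(C)c2ccnc(Cl)n2)cc1OCC[Se]C#N`, 1670 nM
compound 3 `COc1ccc(N(C)c2cc(C)nc(C)n2)cc1`, 824 nM

Compound 3 has the lowest number of the three, and its gaps to compound 2 and to compound 1 both lie beyond the scatter. The next compound to consider is compound 4 `COc1ccc(N(C)c2cc(C)nc(C)n2)cc1Cl`, which differs from compound 3 by chloro in place of hydrogen on an aromatic carbon. This is chloro in place of hydrogen on an aromatic carbon, ortho to a methoxy group and meta to a large group.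

For the measured compounds named here, one measured step concerns that same aromatic carbon: a 1.6-fold lower number from compound 1 to compound 2 (0.20 log units; within the scatter), within the scatter. That step replaces chlorine with a larger group and does not compare chloro with hydrogen, so it bears on the change only indirectly. Compound 1 and compound 3 differ in more than one place, so their gap does not isolate the chloro either. Going by the values given here, no measured pair isolates this change.

No step beyond the scatter is therefore expected in this assay, with a slight lean towards a higher number. That lean rests on compound 1, which carries the chloro and gives 2630 nM. The expected step is a 1.2-fold higher number from compound 3 to compound 4 (0.08 log units; within the scatter). For compound 4 the estimated value is 1000 nM, with an expected range of 350 nM to 3000 nM.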

Compound 4, half-maximal inhibitory concentration: 787 nM
The estimate for compound 4 lay 1.3-fold (0.10 log units) above the measured number; measured number inside the range.
By their numbers in this assay, from the lowest: compounds 4 and 3 (each within the scatter of the next); then compounds 2 and 1 (each within the scatter of the next).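

In this assay, chloro in place of hydrogen on an aromatic carbon, ortho to a methoxy group and meta to a large group, gives a 1.0-fold lower number from compound 3 to compound 4 (0.02 log units; within the scatter) and so leaves no step beyond the scatter on the core of compound 3. This is the first pair shown that compares chloro with hydrogen directly at this position, whereas the earlier step at the same carbon compared chlorine with a larger group and the gap between compound 1 and compound 3 spans more than one place. On the core of compound 3, then, the two substituents cannot be told apart in this assay, and no measurement shown gives a reason for that.

For the compounds shown here, it remains open whether chloro and hydrogen also read alike on the core of compound 1, since only one pair speaks to this change. From the compounds shown here alone, it is also open whether another group on this aromatic carbon of the core of compound 3, such as an amine, a carboxylic acid or a longer chain, would move the number beyond the scatter.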